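Swapping Chloro for Fluoro on a Benzenesulfonamide

A few compounds are considered here, and "the series" means these few. Any claim that something is new, unique, unknown or untested is made for them only; others in the source may bear on it.

Within the data shown here, compound 1, `Cc1ccccc1C(=O)NCc1ccc(CNS(=O)(=O)c2ccc(Cl)cc2)cc1`, is one of two compounds measured in an assay on MDA-MB-231 cells for displacement of a labelled ligand from C-X-C chemokine receptor type 4 (Homo sapiens), read by fluorescence and microscopy, with stated times of 10 min and 30 min; a lower number here means that less compound is needed, a higher number that more compound is needed for the effect. In this assay compound 1 gives 1 nM, the lower of the two numbers. Among the measured compounds shown here, the other measured compound, compound 2, `O=C(NCc1ccc(CNS(=O)(=O)c2cccc(F)c2)cc1)c1cccnc1`, gives 1000 nM in this assay; these two values lie far apart, but compound 2 differs from compound 1 in more than one place, so no single step links them. Compound 3, `Cc1ccccc1C(=O)NCc1ccc(CNS(=O)(=O)c2ccc(F)cc2)cc1`, has not yet been measured. It differs from compound 1 only in this: fluoro in place of chloro on an aromatic carbon. For the measured compounds named here, with no single-point step among the measured compounds to rest on, the step of a 3.0-fold higher number from compound 1 to compound 3 (0.48 log units; beyond the scatter) is expected to be a modest move toward a higher number, possibly not beyond the usual scatter. Compound 3 is therefore expected to give 3 nM in this assay, within 0.5 nM to 20 nM.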

Compound 3, effective concentration (reported as EC, without a stated level of effect): 10 nM
Beside the measured number, compound 3's estimate is 3.3-fold (0.52 log units) below it; the range from low to high includes it.
By their numbers in this assay, from the lowest: compound 1; then compound 3; then compound 2.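

Among these compounds, exchanging 4-chlorophenyl for 4-fluorophenyl gives a 10-fold higher number from compound 1 to compound 3 (1.00 log units; beyond the scatter) in this assay, and this is the first comparison here that isolates a single place. The number therefore responds to which halogen sits on this aromatic carbon, even though the change leaves the counts of heavy atoms, hydrogen-bond donors and hydrogen-bond acceptors the same and introduces no net charge. Nothing in the data shown accounts for the size of this step.

From the compounds shown here alone, whether a bromo or a methyl group on this same aromatic carbon would give a number nearer that of compound 1 or that of compound 3 remains open. This single pair also leaves open whether the same exchange would produce a step of similar size on a core other than that of compound 1.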